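Lengthening the Chain on a Shared Core

The source may hold more compounds than are shown below. What is called first, only, known or untested is meant among the compounds shown, and "the series" means these compounds.

Within the data shown here, compound 2 `CO/C(C)=N\S(=O)(=O)c1ccc(C)cc1` is the only compound with an actual number in an ADME assay on the whole organism (plasma) for pharmacokinetics, with Homo sapiens as the target, in phosphate buffer, at pH 7.4 (a higher number here means that the compound lasts longer, a lower number that the compound disappears faster), where compound 2 gives 0.135 h. Compound 1 `CCO/C=N\S(=O)(=O)c1ccc(C)cc1` in this assay returns only a limit, < 0.0167 h. Among the measured compounds shown here, the one measured step, an at least 8.0-fold higher number from compound 1 to compound 2 (0.90 log units; beyond the scatter), is a change on the sulfonyl sulfur. Compound 3 `CCC/C(=N/S(=O)(=O)c1ccc(C)cc1)OC` differs from compound 2 by ethyl in place of hydrogen on a saturated chain carbon bound to a carbon with a double bond to nitrogen. For the measured compounds named here, no measured step follows this kind of change: the single step at hand exchanges an entire group on the sulfonyl sulfur rather than extending a chain, so it offers no guidance on direction for compound 3. The expected step from compound 2 to compound 3 is therefore small, a 1.5-fold higher number from compound 2 to compound 3 (0.17 log units; within the scatter), with nothing beyond the scatter expected. Compound 3 is estimated at 0.2 h in this assay, with a range from 0.08 h to 0.6 h.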

Compound 3, half-life: 0.533 h
Beside the measured number, compound 3's estimate is 2.7-fold (0.43 log units) below it, within the range that was stated.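

Ethyl in place of hydrogen on a saturated chain carbon bound to a carbon with a double bond to nitrogen gives a 3.9-fold higher number from compound 2 to compound 3 (0.60 log units; beyond the scatter) in this assay. This is the first change shown at this position, and it shows that the half-life responds to a change in the chain here, whereas the earlier step exchanged an entire group on the sulfonyl sulfur. No measurement shown bears on why the half-life rises.

As far as these compounds go, it remains open whether a methyl, a longer chain, or a chain ending in an amine or a carboxylic acid would move the half-life in the same direction. From the compounds shown here alone, it is also open whether the same ethyl would have a comparable effect with a different group on the sulfonyl sulfur.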